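A few compounds are considered here, and "the series" means these few. Any claim that something is new, unique, unknown or untested is made for them only; others in the source may bear on it.

Three compounds built on one shared core differ only in the group attached to the carbon that carries a double bond to nitrogen. In a functional assay on MKN-45 cells (Homo sapiens) for cytotoxicity, read by MTT assay, with a stated time of 72 h (a lower number here means a stronger inhibitor, a higher number a weaker inhibitor), compound 1 `CN(C)CCn1cnnc1-c1cc(Oc2ccc(NC(=O)N/N=C/c3ccccc3)cc2F)ccn1` gives 2730 nM. Compound 2 `COc1cc(/C=N/NC(=O)Nc2ccc(Oc3ccnc(-c4nncn4CCN(C)C)c3)c(F)c2)cc(OC)c1OC` gives 2900 nM, and compound 3 `CN(C)CCn1cnnc1-c1cc(Oc2ccc(NC(=O)N/N=C/c3c(O)ccc4ccccc34)cc2F)ccn1` gives 2020 nM. Compound 3 is the point of departure here, and the other two numbers sit close to it: a 1.4-fold lower number from compound 1 to compound 3 (0.13 log units; within the scatter), and a 1.4-fold lower number from compound 2 to compound 3 (0.16 log units; within the scatter). The step of a 1.1-fold higher number from compound 1 to compound 2 (0.03 log units; within the scatter) also stays within the scatter, so across these three compounds exchanging the group at this carbon has not moved the number by more than the usual spread of repeated measurements.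

Compound 4 `CN(C)CCn1cnnc1-c1cc(Oc2ccc(NC(=O)N/N=C/c3ccc(F)cc3Cl)cc2F)ccn1` has not yet been measured. Its difference from compound 3 is 2-chloro-4-fluorophenyl in place of 2-hydroxynaphthalen-1-yl on a carbon with a double bond to nitrogen. The three measured steps all concern this same position, and each of them lay within the scatter, which gives no footing for expecting a change in this assay beyond it. Compound 4 is expected to give 2500 nM. The range for compound 4 is estimated as 1200 nM to 5500 nM. The expected step of a 1.2-fold higher number from compound 3 to compound 4 (0.09 log units; within the scatter) is a small one, with no clear direction.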

Compound 4, half-maximal inhibitory concentration: 870 nM
For compound 4 the middle estimate is 2.9-fold (0.46 log units) above the measured one, and the stated range ends above it.
By their numbers in this assay, from the lowest: compound 4; then compounds 3, 1 and 2 (each within the scatter of the next).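

In this assay, among the compounds shown here, this position is not as indifferent to change as the first three compounds suggested: with 2-chloro-4-fluorophenyl on the carbon with a double bond to nitrogen, there is a 2.3-fold lower number from compound 3 to compound 4 (0.37 log units; beyond the scatter), the first step here to lie beyond the scatter. The same group also stands apart from the two smaller or differently decorated aryl groups, with a 3.1-fold lower number from compound 1 to compound 4 (0.50 log units; beyond the scatter) and a 3.3-fold lower number from compound 2 to compound 4 (0.52 log units; beyond the scatter), so phenyl, 3,4,5-trimethoxyphenyl and 2-hydroxynaphthalen-1-yl stay within the scatter of one another while 2-chloro-4-fluorophenyl alone separates from all three, though only by a modest margin. No measurement beyond these cell numbers bears on why this one replacement makes a difference.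

Compound 4 brings in chlorine and fluorine together, so the compounds shown cannot say whether the change comes from one halogen, from the other, or only from the pair, which a 2-chlorophenyl or a 4-fluorophenyl group at this carbon would help to separate. On these data alone, it also remains open whether anything other than an aromatic ring, such as a cyclohexyl group or a short alkyl chain, would be tolerated here.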